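Moving a methoxy group around the styryl ring of a chalcone

The compounds below may be only part of what the source reports. "The series", "measured", "known", "first", "only" and "open" are said of these compounds alone.

Measured compounds:
compound 1 `COc1cccc(/C=C/C(=O)c2c(OC)cc(OC)cc2OC)c1` — 4300 nM
compound 2 `COc1cc(OC)c(C(=O)/C=C/c2ccc(Br)cc2)c(OC)c1` — 6200 nM
compound 3 `COc1cccc(/C=C/C(=O)c2c(O)cc(OC)cc2OC)c1` — 7700 nM

In a functional assay on HCT-116 cells (Homo sapiens) for cytotoxicity, with a stated time of 48 h (a higher number here means a weaker inhibitor, a lower number a stronger inhibitor), compound 1 gives the lowest of the three numbers, yet its two neighbours lie within the usual scatter of it: a 1.4-fold higher number from compound 1 to compound 2 (0.16 log units; within the scatter) and a 1.8-fold higher number from compound 1 to compound 3 (0.25 log units; within the scatter). Compound 4 `COc1cc(OC)c(C(=O)/C=C/c2ccccc2OC)c(OC)c1` has not been measured; it differs from compound 1 as follows: 2-methoxyphenyl in place of 3-methoxyphenyl on a double-bonded chain carbon bound to a double-bonded chain carbon. For the measured compounds named here, the only step that bears on this place is the one from compound 1 to compound 2, where a different aryl group at the same position left the number within the scatter. Compound 3 changes a different ring and tells little here. A step of similar size is therefore expected, with no direction beyond the scatter, a 1.2-fold higher number from compound 1 to compound 4 (0.07 log units; within the scatter). Compound 4 is estimated at 5000 nM, within 2000 nM to 13000 nM.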

Compound 4, half-maximal inhibitory concentration: 4200 nM
For compound 4 the middle estimate is 1.2-fold (0.08 log units) above the measured one; the measured number falls inside the stated range.
By their numbers in this assay, from the lowest: compounds 4, 1, 2 and 3 (each within the scatter of the next).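

Swapping 3-methoxyphenyl for 2-methoxyphenyl at this place leaves the number in this assay essentially unchanged (a 1.0-fold lower number from compound 1 to compound 4 (0.01 log units; within the scatter)), so this shift of the methoxy group makes no readable difference. The comparison with 4-bromophenyl also stays within the scatter (a 1.5-fold lower number from compound 2 to compound 4 (0.17 log units; within the scatter)), so compounds 1, 2 and 4 cannot be separated by the aryl group they carry here. No supporting data explain this result. Still open, going by these compounds, is whether 4-methoxyphenyl, or an aryl group carrying an amine or a carboxylic acid, would move the number beyond the scatter.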